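A few compounds are considered here, and "the series" means these few. Any claim that something is new, unique, unknown or untested is made for them only; others in the source may bear on it.

Measured so far in a functional assay on QGY-7703 cells (Homo sapiens) for cytotoxicity, read by MTT assay, with a stated time of 24 h; on this read-out higher numbers stand for weaker inhibition and lower numbers for stronger inhibition:
compound 1, `O=C1/C(=C/c2cccnc2)CN(S(=O)(=O)c2ccc(Br)cc2)C/C1=C\c1ccccc1C(F)(F)F`, giving 5510 nM;
compound 2, `N#Cc1ccc(S(=O)(=O)N2C/C(=C\c3cccnc3)C(=O)/C(=C/c3ccccc3C(F)(F)F)C2)cc1`, giving 6150 nM;
compound 3, `O=C1/C(=C/c2ccncc2)CN(S(=O)(=O)c2ccc(Br)cc2)C/C1=C\c1ccccc1C(F)(F)F`, giving 7060 nM.

Compound 2 arises from compound 1 by cyano in place of bromo on an aromatic carbon, and this gave a 1.1-fold higher number from compound 1 to compound 2 (0.05 log units; within the scatter). Compound 3 arises from compound 1 by a change of the core, (pyridin-4-yl in place of pyridin-3-yl on a double-bonded chain carbon bound to a double-bonded ring carbon), giving a 1.3-fold higher number from compound 1 to compound 3 (0.11 log units; within the scatter). Compound 4, `N#Cc1ccc(S(=O)(=O)N2C/C(=C\c3ccncc3)C(=O)/C(=C/c3ccccc3C(F)(F)F)C2)cc1`, is not yet measured; it arises from compound 3 by cyano in place of bromo on an aromatic carbon, the same change that led from compound 1 to compound 2, now made on the core of compound 3.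

For compound 4 the step from compound 3 is expected to be a 1.1-fold higher number from compound 3 to compound 4 (0.03 log units; within the scatter), because the earlier instance gave a 1.1-fold higher number from compound 1 to compound 2 (0.05 log units; within the scatter). Compound 4 is therefore estimated at 7600 nM in this assay, with a range from 3800 nM to 15000 nM.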

Compound 4, half-maximal inhibitory concentration: 6290 nM
Compound 4: the middle estimate sits 1.2-fold (0.08 log units) above what was measured; the range from low to high includes it.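

In this assay, cyano in place of bromo gave a 1.1-fold lower number from compound 3 to compound 4 (0.05 log units; within the scatter), which matches the earlier instance of this change: the same change on two cores in this assay, a 1.1-fold higher number (0.05 log units; within the scatter) from compound 1 to compound 2 and a 1.1-fold lower number (0.05 log units; within the scatter) from compound 3 to compound 4, 1.3-fold (0.10 log units) apart, within the scatter of two such steps

Pyridin-4-yl in place of pyridin-3-yl gave a 1.0-fold higher number from compound 2 to compound 4 (0.01 log units; within the scatter), and this too matches its earlier instance: the same change on two cores in this assay, a 1.3-fold higher number (0.11 log units; within the scatter) from compound 1 to compound 3 and a 1.0-fold higher number (0.01 log units; within the scatter) from compound 2 to compound 4, 1.3-fold (0.10 log units) apart, within the scatter of two such steps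

Among these compounds, each swap therefore behaves alike on the two cores, but since every step lies within the scatter, this shows only that neither swap shifts the number measurably here, not that a step large enough to read would carry from one core to another.

The compounds shown leave open what an amine or a carboxylic acid in place of bromo would do. They also leave open whether replacing trifluoromethyl with another group would shift the number.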